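Lengthening the amine chain by one carbon

A few compounds are considered here, and "the series" means these few. Any claim that something is new, unique, unknown or untested is made for them only; others in the source may bear on it.

Measured so far:
Compound 1 `CN(C)CCCCC(=O)N(O)CCC(=O)O` gives 18000 nM in an assay on isolated protein for inhibition of lysine-specific demethylase 5A (Homo sapiens), with a stated time of 60 min; on this read-out higher numbers stand for weaker inhibition and lower numbers for stronger inhibition.
Compound 2 `CCCCCN(C)CCCCC(=O)N(O)CCC(=O)OC` gives 63000 nM in this assay.

Compound 2 stands highest of the two numbers in this assay; compound 1 shows a lower value, but the two differ in more than one place, so their gap cannot be traced to one change. Compound 3 `CCCCCCN(C)CCCCC(=O)N(O)CCC(=O)OC` differs from compound 2 by methyl in place of hydrogen on a saturated chain carbon, five bonds along the chain from an amine nitrogen. Among the measured compounds shown here, no single-change step between measured compounds is available, so the expectation rests on the change itself: one added chain carbon is expected to move the number little, in either direction, within the usual scatter. Compound 3 is therefore expected at 70000 nM, between 25000 nM and 200000 nM, an expected step of a 1.1-fold higher number from compound 2 to compound 3 (0.05 log units; within the scatter).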

Compound 3, half-maximal inhibitory concentration: 21000 nM
Beside the measured number, compound 3's estimate is 3.3-fold (0.52 log units) above it; the whole stated range lies above it.
By their numbers in this assay, from the lowest: compounds 1 and 3 (each within the scatter of the next); then compound 2.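

In this assay the chain extension gives a 3.0-fold lower number from compound 2 to compound 3 (0.48 log units; beyond the scatter) and so shows that this position responds to methyl in place of hydrogen. Among the compounds shown, this is the only single-change step, and although modest, it lies beyond the scatter, so one added chain carbon here is not a silent change. No measurement shown explains the shift. Going by these compounds, whether a heptyl chain on the amine nitrogen would lower the number further remains open. So does how a benzyl group there would compare.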